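This account rests on a few compounds, and the source may have more. Where it says the series, first, only, none or still open, it means among the compounds named here.

Among the measured compounds shown here, in a functional assay on BXPC-3 cells (Homo sapiens) for antiproliferative activity, read by MTT assay, with a stated time of 24 h (on this read-out lower numbers stand for stronger inhibition and higher numbers for weaker inhibition), compound 1 `CCn1c(C(=O)N[C@@H](C)CO)ccc1C(CC)(CC)c1ccc(OCS(=O)(=O)c2ccccc2)c(C)c1` gives 15300 nM and compound 2 `CCn1c(C(=O)N[C@H](CO)CCO)ccc1C(CC)(CC)c1ccc(OCS(=O)(=O)c2ccccc2)c(C)c1` gives 15900 nM, so compound 2 stands level with its only measured neighbour. Compound 3 `CCn1c(C(=O)N[C@H](C)C(=O)O)ccc1C(CC)(CC)c1ccc(OCS(=O)(=O)c2ccccc2)c(C)c1` differs from compound 2 by 1-carboxyethyl in place of 3-hydroxy-1-(hydroxymethyl)propyl on an amide-type nitrogen, with 1-carboxyethyl in place of 3-hydroxy-1-(hydroxymethyl)propyl on an amide-type nitrogen. For the measured compounds named here, the only measured step, a 1.0-fold higher number from compound 1 to compound 2 (0.02 log units; within the scatter), lies within the scatter and concerns a single hydroxymethyl, and no measured compound carries 1-carboxyethyl. The evidence is thin, so only a small move towards a higher number is expected, a 1.4-fold higher number from compound 2 to compound 3 (0.14 log units; within the scatter). Compound 3 is estimated at 22000 nM, with an expected range of 9000 nM to 55000 nM.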

Compound 3, half-maximal inhibitory concentration: 20100 nM
Compound 3: the middle estimate sits 1.1-fold (0.04 log units) above what was measured; the range from low to high includes it.
By their numbers in this assay, from the lowest: compounds 1, 2 and 3 (each within the scatter of the next).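

In this assay, 1-carboxyethyl on the amide-type nitrogen stands level with both hydroxyl-bearing groups: replacing 3-hydroxy-1-(hydroxymethyl)propyl gives a step within the scatter (a 1.3-fold higher number from compound 2 to compound 3 (0.10 log units; within the scatter)), and replacing 1-(hydroxymethyl)ethyl does the same (a 1.3-fold higher number from compound 1 to compound 3 (0.12 log units; within the scatter)). The position thus tolerates a carboxyl group in place of these hydroxyl groups without a change that can be read. No available evidence explains this result. The compounds shown leave open whether an amine or a longer chain at this nitrogen would move the number beyond the scatter.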